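Shortening a Hydroxyalkyl Chain on an Inactive Core

The source may report more compounds than this note shows. Statements on the series, on what has been measured and on what is new or still open speak of the compounds shown alone.

Compound 1, `Cn1nc(CCO)ccc1=O`, in a functional assay on aorta (Rattus norvegicus) (a lower number here means a stronger inhibitor, a higher number a weaker inhibitor), gives > 100000 nM, which is a limit of the assay and not a number.
Compound 2, `O=c1ccc(CCCO)n[nH]1`, gives > 100000 nM, again a limit.
Compound 3, `Cn1nc(CCCO)ccc1=O`, gives > 100000 nM, also a limit.

Compound 2 therefore stands nowhere on a numerical scale: its value is only a limit, and the two other values shown are limits as well, all three sitting at the same point (the limit of > 100000 nM in this assay, at which 3 of the 3 values shown sit). None of the three compounds can be ranked against another.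

Compound 4, `O=c1ccc(CCO)n[nH]1`, differs from compound 2 by hydroxy in place of hydroxymethyl on a saturated chain carbon, two bonds along the chain from an aromatic carbon. For the measured compounds named here, two measured steps bear on this change. The step that the two limits leave unreadable from compound 1 to compound 3 is the reverse of the same chain change, on the core that carries a methyl on the aromatic nitrogen. The step that the two limits leave unreadable from compound 2 to compound 3 links compound 2 to that core. Both steps are unreadable because every value involved sits at the limit (the limit of > 100000 nM in this assay, at which 3 of the 3 values shown sit). Going by the values given here, no size or direction of step in this assay can therefore be derived; the only expectation is that compound 4 also shows no measurable inhibition. Compound 4 is estimated at 150000 nM, with a range from 50000 nM to 500000 nM. The step that the limit leaves unreadable from compound 2 to compound 4 is thus expected to be unreadable, with the result most likely reported as a limit again.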

Compound 4, half-maximal inhibitory concentration: > 100000 nM
Compound 4: a limit, no number; the forecaster's own chance of this, stated with the estimate: 85%; the middle value lies beyond the limit too.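

In this assay compound 4 gives > 100000 nM, a limit of the assay and not a number. No step linking compound 4 to compound 1 or compound 2 can be read, because every value shown sits at the same point: the limit of > 100000 nM in this assay, at which 4 of the 4 values shown sit.

The compounds shown leave open which structural change, if any, would bring inhibition into the readable range of this assay.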